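This account rests on a few compounds, and the source may have more. Where it says the series, first, only, none or still open, it means among the compounds named here.

Measured compounds in an assay on membranes from brain for binding affinity to Fatty-acid amide hydrolase 1 (Mus musculus), read by fluorescence, with stated times of 1 h and 30 min; a higher number here means a weaker inhibitor, a lower number a stronger inhibitor:

Compound 1, `CN(CCN(C)C(=O)n1cccn1)Cc1ccc(OCc2ccccc2)cc1`, gives 510 nM.
Compound 2, `CN(CCN(C)C(c1ccc(OCc2ccccc2)cc1)c1ccc(OCc2ccccc2)cc1)C(=O)n1cc(C#N)cn1`, reaches only the assay limit of > 1000000 nM.
Compound 3, `Cc1cnn(C(=O)N2CCN(C(c3ccc4ccccc4c3)c3ccc4ccccc4c3)CC2)c1`, reaches only the assay limit of > 100000 nM.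

Compound 3 therefore stands at a limit, not at a number, and so does compound 2; only compound 1 shows a measured value. Compound 4, `O=C(N1CCN(C(c2ccc3ccccc3c2)c2ccc3ccccc3c2)CC1)n1cccn1`, differs from compound 3 in one place: hydrogen in place of methyl on an aromatic carbon, (hydrogen in place of methyl on an aromatic carbon). Among the measured compounds shown here, no step between measured compounds is available to size this change. Compound 4 is expected to remain very weak, so the step of an at least 2.0-fold lower number from compound 3 to compound 4 (0.30 log units; that floor lies within the scatter) is an estimate of little change beyond the scatter. For compound 4 the expected value is 50000 nM, in the range 2000 nM to 1000000 nM.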

Compound 4, half-maximal inhibitory concentration: > 100000 nM
Compound 4: only a limit was reported; the forecaster's own chance of this, stated with the estimate: 60%; middle value at least 2.0-fold (0.30 log units) from the limit.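

No step from compound 3 to compound 4 can be read, because both stop at the same limit rather than at a number: the limit of > 100000 nM in this assay, at which 2 of the 4 values shown sit.

From the compounds shown here alone, whether swapping 4-methyl-1H-pyrazol-1-yl for 1H-pyrazol-1-yl changes binding at all remains open.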